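The source may report more compounds than this note shows. Statements on the series, on what has been measured and on what is new or still open speak of the compounds shown alone.

Going by the values given here, the three compounds measured so far share one core and were all tested in a functional assay for inhibition, with Homo sapiens as the target; a higher number here means a weaker inhibitor, a lower number a stronger inhibitor. Compound 1 `CCCCc1nnc(O)n2c(CCC)nc(C)c12` gives only a limit of the assay, > 48000 nM, and not a number. Compound 2 `C=CCn1nc(C)c2c(C)nc(CCC)n2c1=O` gives several entries, 69000 nM; > 48000 nM (2 entries), as shown by the several entries of compound 2 in this assay, 69000 nM; > 48000 nM (2 entries). Compound 3 `CSc1nncc2c(C)nc(C(C)C)n12` likewise gives only a limit, > 48000 nM. Where compound 3 stands cannot be told from these results: it has no number of its own, one further value is a limit too (the limit of > 48000 nM in this assay, at which 2 of the 3 values shown sit), and the remaining entry also yields no single number.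

Compound 4 `CCc1nc(C)c2cnnc(SC)n12` differs from compound 3 in one place: hydrogen in place of methyl on a saturated chain carbon bound to an aromatic carbon and a saturated chain carbon, which cut one bond further out reads isopropyl to ethyl. Among the compounds with values here, no step between two measured compounds is available to judge such a change, and everything measured so far sits at or near the same limit. The step is therefore expected to be a step that the limit leaves unreadable from compound 3 to compound 4, nothing beyond the scatter, and the result is most likely again a limit. Compound 4 is estimated at 60000 nM, with a range from 20000 nM to 200000 nM.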

Compound 4, half-maximal inhibitory concentration: > 48000 nM
Compound 4 ended at the assay's limit; the forecaster's own chance of this, stated with the estimate: 85%; the middle value does not contradict the limit.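

In this assay, compound 3 and compound 4 each give only a limit and not a number, and the step between them, isopropyl to ethyl, cannot be read. The compounds shown leave open whether any change on the shared core gives a stronger inhibitor than this limit allows to be seen, with most results resting on one value: the limit of > 48000 nM in this assay, at which 3 of the 4 values shown sit.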